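The source may report more compounds than this note shows. Statements on the series, on what has been measured and on what is new or still open speak of the compounds shown alone.

Measured compounds in an ADME assay on MT2 cells (Homo sapiens) for cytotoxicity; a lower number here means that less compound is tolerated, a higher number that more compound is tolerated:
- compound 1, `COc1cc(CNC(=O)c2cc3nc(C)c([C@H](OC(C)(C)C)C(=O)O)c(-c4cc(F)c5c(c4C)CCCO5)n3n2)ccc1F`: > 20000 nM
- compound 2, `COc1cc(F)ccc1CNC(=O)c1cc2nc(C)c([C@H](OC(C)(C)C)C(=O)O)c(-c3cc(F)c4c(c3C)CCCO4)n2n1`: > 40000 nM
- compound 3, `Cc1nc2cc(C(=O)NCC3CCCCC3)nn2c(-c2cc(F)c3c(c2C)CCCO3)c1[C@H](OC(C)(C)C)C(=O)O`: > 40000 nM

Going by the values given here, every value so far is a limit of the assay, not a number. Compound 1 stands at a limit, (the limit of > 20000 nM in this assay, at which 1 of the 3 values shown sits). Compound 2 sits at a limit of the assay. Compound 3 sits at a limit of the assay as well, (the limit of > 40000 nM in this assay, at which 2 of the 3 values shown sit). Between these three nothing can be ordered: a step that the two limits leave unreadable from compound 1 to compound 2, a step that the two limits leave unreadable from compound 1 to compound 3 and a step that the two limits leave unreadable from compound 2 to compound 3 are all unreadable, since both ends of each step are limits. The two changes already made on the saturated chain carbon bound to the amide-type nitrogen, to a 4-fluoro-2-methoxyphenyl and to a cyclohexyl, therefore gave no readable effect.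

Compound 4, `Cc1nc2cc(C(=O)NCCC3CCOCC3)nn2c(-c2cc(F)c3c(c2C)CCCO3)c1[C@H](OC(C)(C)C)C(=O)O`, differs from compound 1 by (oxan-4-yl)methyl in place of 4-fluoro-3-methoxyphenyl on a saturated chain carbon bound to an amide-type nitrogen. The measured steps that bear on it are the three above, none of which is readable, so no step beyond the scatter is expected in this assay, in either direction, and the most probable outcome is once more a limit. Compound 4 is expected to give 40000 nM, with a range of 20000 nM to 100000 nM. The expected step that the limit leaves unreadable from compound 1 to compound 4 is an estimate that rests only on the three limits.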

Compound 4, half-maximal cytotoxic concentration: > 40000 nM
Compound 4 gave a limit, no number; the forecaster's own chance of this, stated with the estimate: 85%; the middle value lies on the limit itself.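

Compound 4 gives > 40000 nM, a limit of the assay. No new step can be read between compound 4 and compound 1, compound 2 or compound 3. From the compounds shown here alone, with all four values at limits, it remains open whether any group on the saturated chain carbon bound to an amide-type nitrogen changes the tolerated concentration.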